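Adding a methyl to the anilide of compound 3

The source may hold more compounds than are shown below. What is called first, only, known or untested is meant among the compounds shown, and "the series" means these compounds.

Measured so far in a functional assay on A549 cells (Homo sapiens) for cytotoxicity, read by WST assay, with a stated time of 72 h; a lower number here means a stronger inhibitor, a higher number a weaker inhibitor:
compound 1 `COc1cc2c(Nc3nc4ccc(C(=O)Nc5c(C)cc(C)cc5C)cc4s3)ncnc2cc1OCCCN1CCC(C)CC1`: 5400 nM
compound 2 `COc1cc2c(Nc3nc4ccc(C(=O)Nc5c(C)cccc5Cl)cc4s3)ncnc2cc1OCCCN1CCCCC1C`: 6700 nM
compound 3 `COc1cc2c(Nc3nc4ccc(C(=O)Nc5c(C)cccc5C)cc4s3)ncnc2cc1OCCCN1CCCCC1C`: 75700 nM

Compound 3 gives the highest number of the three; compound 2 stands nearest and compound 1 furthest, both beyond the scatter. Among the compounds with values here, the only one-place step recorded is an 11-fold higher number from compound 2 to compound 3 (1.05 log units; beyond the scatter), which concerns a chloro-to-methyl exchange and does not touch the change examined here.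

Compound 4 `COc1cc2c(Nc3nc4ccc(C(=O)Nc5c(C)cc(C)cc5C)cc4s3)ncnc2cc1OCCCN1CCCCC1C` differs from compound 3 by methyl in place of hydrogen on an aromatic carbon. Within the data shown here, no measured step covers this exact change. What bears on it is that compound 1, which carries the same (2,4,6-trimethylphenyl)carbamoyl group on a core differing only in its piperidine, gives 5400 nM, well under the number for compound 3.

On that basis a downward step a 6.3-fold lower number from compound 3 to compound 4 (0.80 log units; beyond the scatter) is expected, landing compound 4 between the numbers of compound 1 and compound 3. The estimate for compound 4 in this assay is 12000 nM, with a range from 4000 nM to 40000 nM.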

Compound 4, half-maximal inhibitory concentration: 5800 nM
Compound 4: middle estimate off by 2.1-fold (0.32 log units), on the high side; measured number inside the range.
By their numbers in this assay, from the lowest: compounds 1, 4 and 2 (each within the scatter of the next); then compound 3.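

In this assay, the aromatic carbon para to a large group proves sensitive on the 2,6-dimethylphenyl anilide: methyl in place of hydrogen gives a 13-fold lower number from compound 3 to compound 4 (1.12 log units; beyond the scatter), a large step in this series. With the 2,4,6-trimethylphenyl group present, 2-methylpiperidin-1-yl and 4-methylpiperidin-1-yl are not told apart, with a 1.1-fold higher number from compound 1 to compound 4 (0.03 log units; within the scatter), so the high number of compound 3 does not carry over to compound 4 despite the shared 2-methylpiperidin-1-yl group. The 2,4,6-trimethylphenyl and 2-chloro-6-methylphenyl anilides are also not told apart, with a 1.2-fold lower number from compound 2 to compound 4 (0.06 log units; within the scatter).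

From the compounds shown here alone, whether ethyl, methoxy or chloro on that same aromatic carbon would give a step of similar size remains open. The data shown offer no evidence on the cause of these steps.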